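The compounds below may be only part of what the source reports. "The series", "measured", "known", "first", "only" and "open" are said of these compounds alone.

Compound 1 `O=C1C=COC(/C=C/c2ccc(C(F)(F)F)cc2)C1`: in a functional assay on NCI-H460 cells (Homo sapiens) for inhibition, read by sulforhodamine B assay, with a stated time of 48 h (on this read-out lower numbers stand for stronger inhibition of growth and higher numbers for weaker inhibition of growth), compound 1 gives 95.6 uM.
Compound 2 `COc1ccc(/C=C/C2CC(=O)C=CO2)cc1`: in this assay compound 2 gives 149 uM.
Compound 3 `O=C1C=CCC(/C=C/c2ccc(C(F)(F)F)cc2)N1`: in this assay compound 3 gives 150 uM.

All three measured compounds are weak in this assay, and their numbers lie within the scatter of one another, so no order among them can be claimed. Compound 1 and compound 2 share a core and differ in one place: methoxy in place of trifluoromethyl on an aromatic carbon. This change gave a 1.6-fold higher number from compound 1 to compound 2 (0.19 log units; within the scatter), a step that stays within the scatter of repeated measurements.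

Compound 3 carries a different core from compound 1; the difference between the two cores is not broken down here. Compound 4 `COc1ccc(/C=C/C2CC=CC(=O)N2)cc1` has not yet been measured. It stands to compound 3 as compound 2 stands to compound 1, by the same change: methoxy in place of trifluoromethyl on an aromatic carbon. This change occurs twice among the compounds shown, once measured and once not.

Among the measured compounds shown here, because the one measured instance gave a 1.6-fold higher number from compound 1 to compound 2 (0.19 log units; within the scatter), compound 4 is expected to show a step of similar size from compound 3, namely a 1.5-fold higher number from compound 3 to compound 4 (0.19 log units; within the scatter). This rests on a single pair, so the expectation is loose. Given 150 uM for compound 3, the estimate for compound 4 in this assay is 230 uM, with a plausible range from 120 uM to 450 uM.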

Compound 4, concentration for growth inhibition (reported as GI): > 1090 uM
Compound 4: a limit, no number; the forecaster's own chance of this, stated with the estimate: 15%; middle value at least 4.7-fold (0.67 log units) away from the limit.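

In this assay compound 4 gives > 1090 uM, which is a limit of the assay and not a number. Methoxy in place of trifluoromethyl on an aromatic carbon gave an at least 7.2-fold higher number from compound 3 to compound 4 (0.86 log units; beyond the scatter), so in this series the effect of the change did not carry over in size from the core of compound 1 to the core of compound 3: the same change on two cores in this assay, a 1.6-fold higher number (0.19 log units; within the scatter) from compound 1 to compound 2 and an at least 7.2-fold higher number (0.86 log units; beyond the scatter) from compound 3 to compound 4, at least 4.6-fold (0.66 log units) apart, beyond the scatter of two such steps This does not show how large the step on the core of compound 3 really is, since only its lower bound can be read, and with a single pair on each core it gives no general rule for how the change behaves on other cores.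

The compounds shown leave open whether the gap between the two cores is peculiar to methoxy and trifluoromethyl, or whether another group on the same aromatic carbon, such as a nitrile, a chlorine or a dimethylamino group, would also give steps that differ from one core to the other. They also leave open whether the same gap would appear on other cells or on any read-out other than growth inhibition.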